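The source may hold more compounds than are shown below. What is called first, only, known or untested is meant among the compounds shown, and "the series" means these compounds.

Measured in an ADME assay on BJ cells (Homo sapiens) for cytotoxicity, with a stated time of 72 h; on this read-out lower numbers stand for an effect already at smaller amounts and higher numbers for an effect only at larger amounts of compound:
compound 1 `C=C[C@@](C)(/C=C/c1ccc(Nc2ccccc2)cc1)CCC=C(C)C`: > 36600 nM, a limit
compound 2 `C=C[C@@](C)(/C=C/c1ccc(-c2ccccc2)cc1)CCC=C(C)C`: > 36600 nM, a limit

Compound 2 has no numerical value on this read-out, only the limit > 36600 nM. The same holds for both measured compounds: the limit of > 36600 nM in this assay, at which 2 of the 2 values shown sit. Among the compounds with values here, the one measured step, a step that the two limits leave unreadable from compound 1 to compound 2, therefore offers no size to carry forward, and it concerns a different change.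

Compound 3 `C=C[C@@](C)(/C=C/c1ccc(-c2ccc(F)cc2)cc1)CCC=C(C)C` differs from compound 2 at one place: fluoro in place of hydrogen on an aromatic carbon. This is fluoro in place of hydrogen on an aromatic carbon, or phenyl to 4-fluorophenyl. Within the data shown here, no measured step covers this change, so no shift beyond the scatter is expected in this assay, and a further limit is the likeliest report. The expected step is a step that the limit leaves unreadable from compound 2 to compound 3. The estimated value for compound 3 is 40000 nM, with an expected range of 15000 nM to 80000 nM.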

Compound 3, half-maximal effective concentration: > 36600 nM
Compound 3: no number, only a limit; the forecaster's own chance of this, stated with the estimate: 85%; the middle value lies beyond the limit too.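

In this assay compound 3 gives > 36600 nM, a limit and not a number. No step can be read among compound 1, compound 2 and compound 3: the limit of > 36600 nM in this assay, at which 3 of the 3 values shown sit. From the compounds shown here alone, whether these three compounds differ at all in this assay stays open.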